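Adding a Second Fluoro Group to Compound 3

The source may report more compounds than this note shows. Statements on the series, on what has been measured and on what is new or still open speak of the compounds shown alone.

Compound 3 `COc1ccc(C(=O)c2cc(OC)c(OC)c(OC)c2)cc1NC(=O)/C=C/c1ccc(F)cc1` gives the lowest of three numbers measured in a functional assay on DU-145 cells (Homo sapiens) for cytotoxicity, read by MTT assay, with a stated time of 72 h (on this read-out higher numbers stand for weaker inhibition and lower numbers for stronger inhibition), at 3900 nM. Compound 1 `COc1ccc(C(=O)c2cc(OC)c(OC)c(OC)c2)cc1NC(=O)/C=C/c1cc(OC)c(OC)c(OC)c1` gives 6300 nM, and compound 2 `COc1ccc(/C=C/C(=O)Nc2cc(C(=O)c3cc(OC)c(OC)c(OC)c3)ccc2OC)cc1` gives 12800 nM. The step of a 1.6-fold lower number from compound 1 to compound 3 (0.21 log units; within the scatter) lies within the scatter, whereas a 3.3-fold lower number from compound 2 to compound 3 (0.52 log units; beyond the scatter) is a modest change. Compound 4 `COc1ccc(C(=O)c2cc(OC)c(OC)c(OC)c2)cc1NC(=O)/C=C/c1ccc(F)c(F)c1` differs from compound 3 by fluoro in place of hydrogen on an aromatic carbon. Among the measured compounds shown here, no measured step adds a fluoro group to a ring already carrying one; the steps available only exchange whole aryl substituents, and they lean weakly toward fluoro lowering the number. Compound 4 is therefore expected to show a 1.3-fold lower number from compound 3 to compound 4 (0.11 log units; within the scatter), a step within the scatter. Compound 4 is estimated at 3000 nM, ranging from 1500 nM to 6000 nM.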

Compound 4, half-maximal inhibitory concentration: 10200 nM
Estimate against measurement, compound 4: 3.4-fold (0.53 log units) below; measured number above the stated range.
By their numbers in this assay, from the lowest: compounds 3, 1, 4 and 2 (each within the scatter of the next, the first and the last beyond it).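

In this assay, fluoro in place of hydrogen on an aromatic carbon, ortho to a fluoro group, gives a change beyond the scatter: a 2.6-fold higher number from compound 3 to compound 4 (0.42 log units; beyond the scatter). The 3,4-difluorophenyl group does not keep the standing of 4-fluorophenyl, and compound 4 instead lies within the scatter of the other two aryl variants, with a 1.3-fold lower number from compound 2 to compound 4 (0.10 log units; within the scatter) and a 1.6-fold higher number from compound 1 to compound 4 (0.21 log units; within the scatter). Nothing available explains this step. Going by these compounds, it remains open whether the step is specific to fluoro or would also follow from a chloro, methyl or hydroxyl group at this position.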